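The compounds below may be only part of what the source reports. "The series", "measured", "known", "first", "only" and "open" are said of these compounds alone.

In an assay on HEK293 cells for binding affinity to 5-hydroxytryptamine receptor 7 (Homo sapiens), read by radioligand binding, tested at 1 uM (on this read-out lower numbers stand for less inhibition and higher numbers for more inhibition at the one concentration tested (going by the name of the read-out)), compound 1 `CN1CCCN(CCn2ccc3ccc(N)cc32)CC1` gives 0%, and compound 2 `CN1CCCN(CCn2ccc3ccc(C(F)(F)F)cc32)CC1` gives 89%, the higher of the two numbers measured. For the measured compounds named here, the one measured step, a number 89 percentage points higher from compound 1 to compound 2 (beyond the scatter), is large. Compound 3 `CN1CCCN(CCn2ccc3ccc(OCc4ccccc4)cc32)CC1` differs from compound 2 by benzyloxy in place of trifluoromethyl on an aromatic carbon. Neither measured compound carries benzyloxy, so that single step is only a loose guide to what the new group will do at this position. A moderate drop is expected, an estimated step of a number 24 percentage points lower from compound 2 to compound 3 (beyond the scatter). Compound 3 is therefore estimated at 65%, with a likely range from 30% to 95%.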

Compound 3, a percentage reported as inhibition, at one concentration (the size of the read-out at that concentration, not a potency): 28%
Compound 3: middle estimate off by 37 percentage points, on the high side; measured number below the stated range.
By their numbers in this assay, from the lowest: compound 1; then compound 3; then compound 2.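

In this assay, this position now has three groups to compare, with a number 61 percentage points lower from compound 2 to compound 3 (beyond the scatter) on leaving trifluoromethyl and a number 28 percentage points higher from compound 1 to compound 3 (beyond the scatter) on leaving amino, so benzyloxy ranks in the middle. A group with an added aromatic ring therefore keeps part of the inhibition here, but far from all that trifluoromethyl gives.

On these data alone, whether a smaller ether such as methoxy, a halogen such as chlorine, or a nitrile would come closer to trifluoromethyl remains open. Nothing available explains the order of these three groups.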